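The compounds below may be only part of what the source reports. "The series", "measured", "known", "first", "only" and "open" are said of these compounds alone.

Compound 1 `Nc1ccc(-c2cn(Cc3cc(C(=O)O)cc(-c4ccccc4C(=O)O)c3)nn2)cc1` was tested in an assay on cells for inhibition of ubiquitin carboxyl-terminal hydrolase isozyme L5 (Homo sapiens), read by fluorescence, with a stated time of 30 min (a higher number here means a weaker inhibitor, a lower number a stronger inhibitor), where compound 1 gives 80500 nM. Among the compounds with values here, that is the lowest of the two numbers measured so far; the nearest is compound 2 `O=C(O)c1cc(Cn2cc(-c3ccc(NCc4ccccc4)cc3)nn2)cc(-c2ccccc2C(=O)O)c1`, which in this assay gives 215000 nM, and the step of a 2.7-fold higher number from compound 1 to compound 2 (0.43 log units; beyond the scatter) comes from benzyl in place of hydrogen on a nitrogen on an aromatic ring. Compound 3 `Nc1ccc(-c2cn(Cc3cccc(-c4ccccc4C(=O)O)c3)nn2)cc1` has not yet been measured. It differs from compound 1 in one place: hydrogen in place of carboxy on an aromatic carbon. Within the data shown here, no measured step removes or adds a carboxy, so the single step in hand, a 2.7-fold higher number from compound 1 to compound 2 (0.43 log units; beyond the scatter), concerns a different part of the shared core and gives no direct guide. Among the measured compounds shown here, with no comparable step, the number for compound 3 is expected to change little, if at all, beyond the scatter. For compound 3 the expected step is a 1.5-fold higher number from compound 1 to compound 3 (0.17 log units; within the scatter). Compound 3 is therefore estimated at 120000 nM, with a range from 40000 nM to 400000 nM.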

Compound 3, half-maximal inhibitory concentration: 116000 nM
Compound 3: the middle estimate sits 1.0-fold (0.01 log units) above what was measured; the measured number falls inside the stated range.
By their numbers in this assay, from the lowest: compounds 1, 3 and 2 (each within the scatter of the next, the first and the last beyond it).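

In this assay, putting hydrogen in place of the carboxy on an aromatic carbon, meta to a 2-carboxyphenyl group, gives a step that stays within the usual variation between repeat measurements (a 1.4-fold higher number from compound 1 to compound 3 (0.16 log units; within the scatter)). Compounds 1 and 2 both carry this carboxy, so they could not show that, for this pair, the number can be read as unchanged without it, even though the carboxy of the 2-carboxyphenyl group remains in both compounds of the step. No measurement here explains this result.

On these data alone, it remains open whether a methyl ester, an amide or an amine at this position would also leave the number in place. As far as these compounds go, it is also open whether the carboxy of the 2-carboxyphenyl group could be replaced by hydrogen with as small a step.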